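Chloro in Place of Methyl: Outlook for Cytotoxicity

The compounds below may be only part of what the source reports. "The series", "measured", "known", "first", "only" and "open" are said of these compounds alone.

Compound 1, `Cc1cccc(Cn2cc(COc3ccc4c(=O)ccoc4c3)nn2)c1`, gives > 300000 nM in an ADME assay on L02 cells (Homo sapiens) for cytotoxicity, read by MTT assay, with a stated time of 48 h (on this read-out higher numbers stand for weaker inhibition and lower numbers for stronger inhibition), which is a limit of the assay and not a number.
Compound 2, `Cc1ccc(Cn2cc(COc3ccc4c(=O)ccoc4c3)nn2)cc1`, gives > 300000 nM in this assay, again a limit of the assay rather than a number.

Within the data shown here, compound 1 therefore stands at the edge of what this assay can report: both measured values sit at the limit of > 300000 nM in this assay, at which 2 of the 2 values shown sit, and the only measured step, a step that the two limits leave unreadable from compound 1 to compound 2, cannot be read in size or direction because both of its ends are limits.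

Compound 3, `O=c1ccoc2cc(OCc3cn(Cc4cccc(Cl)c4)nn3)ccc12`, differs from compound 1 by chloro in place of methyl on an aromatic carbon. Among the measured compounds shown here, no measured step follows a chloro-for-methyl change, and the one step that exists is unreadable, so there is nothing to carry over except the standing of compound 1 at the limit.

Compound 3 is therefore expected to remain at or near that limit, with an estimated value of 300000 nM and a range from 100000 nM to 1000000 nM. The expected step is a number no higher from compound 1 to compound 3 (the limit leaves the size open), which is to say no step beyond the scatter is expected.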

Compound 3, half-maximal inhibitory concentration: > 300000 nM
Compound 3: no number, only a limit; the forecaster's own chance of this, stated with the estimate: 80%; the middle value lies on the limit itself.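

Among these compounds, compound 1, compound 2 and compound 3 each give a limit of the assay and not a number, so no step between them can be read in size or direction: the limit of > 300000 nM in this assay, at which 3 of the 3 values shown sit.

These compounds leave open how far each one lies beyond that limit, and whether chloro in place of methyl changes the cytotoxicity at all.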